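This account rests on a few compounds, and the source may have more. Where it says the series, first, only, none or still open, it means among the compounds named here.

Working notes on the triazene amide series in a functional assay on HeLa cells (Homo sapiens) for cytotoxicity, read by MTT assay, with a stated time of 72 h; on this read-out higher numbers stand for weaker inhibition and lower numbers for stronger inhibition.

Three compounds carry a number in this assay. Compound 1 `CC(=O)Oc1ccc(/C=C/C(=O)N(/N=N/c2ccc(Cl)c(C(F)(F)F)c2)c2ccc(Cl)c(C(F)(F)F)c2)cc1OC(C)=O` gives in this assay 43000 nM. Compound 2 `CC(=O)N(/N=N/c1ccc([N+](=O)[O-])cc1)c1ccc([N+](=O)[O-])cc1` gives in this assay 63000 nM. Compound 3 `CC(=O)N(/N=N/c1ccc([N+](=O)[O-])cc1Br)c1ccc([N+](=O)[O-])cc1Br` gives in this assay 550 nM, the lowest of the three numbers; the gaps to compound 1 and to compound 2 both lie well beyond the usual scatter, so compound 3 stands apart as the strongest inhibitor among the measured set. Within the data shown here, no two of the measured compounds differ in one place only, so no single-point step in this assay has been observed yet.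

Compound 4 `CC(=O)OCC(=O)N(/N=N/c1ccc([N+](=O)[O-])cc1Br)c1ccc([N+](=O)[O-])cc1Br` is not yet measured. It differs from compound 3 by acetoxy in place of hydrogen on a saturated chain carbon bound to a carbonyl carbon. Among the measured compounds shown here, nothing among the measured compounds shows what a change at this position does; the three numbers give no guide to the direction of such a step. In this assay a step of a 1.6-fold higher number from compound 3 to compound 4 (0.21 log units; within the scatter) is expected, a mild rise in the number that may well stay within the scatter. Compound 4 is estimated at 900 nM, with a range from 250 nM to 3500 nM.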

Compound 4, half-maximal inhibitory concentration: 490 nM
The estimate for compound 4 lay 1.8-fold (0.26 log units) above the measured number; the measured number falls inside the stated range.
By their numbers in this assay, from the lowest: compounds 4 and 3 (each within the scatter of the next); then compounds 1 and 2 (each within the scatter of the next).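

In this assay the change from methyl to acetoxymethyl, which puts acetoxy in place of hydrogen on a saturated chain carbon bound to a carbonyl carbon, gives a 1.1-fold lower number from compound 3 to compound 4 (0.05 log units; within the scatter). Among these compounds, this is the only single-point step so far, and it shows that this position can carry acetoxy, with its 4 heavy atoms and 2 hydrogen-bond acceptors, without a change in the number that stands out from the scatter, which the earlier compounds could not show. No accompanying measurement bears on this result, so it stands as an observation without an explanation.

As far as these compounds go, whether the same holds for other groups on this carbon remains open: a hydroxyl, an amine, a carboxylic acid or a longer chain such as propionyloxy could each behave differently from acetoxy. From the compounds shown here alone, it is equally open whether acetoxy in place of hydrogen at this position would give a similar result on the core of compound 2, which carries the same acetyl group.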